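Working notes: carbamoyl to methoxycarbonyl on compound 1

The source may report more compounds than this note shows. Statements on the series, on what has been measured and on what is new or still open speak of the compounds shown alone.

- Compound 1 `Cc1cc(NC(=O)Nc2cccc(C(N)=O)c2)c2ccccc2n1` gives 100 nM as measured
- Compound 2 `COc1ccc(NC(=O)Nc2cc(C)nc3ccccc23)cc1Cl` gives 400 nM as measured

In a physicochemical assay for solubility, at pH 7.4 (a higher number here means a more soluble compound, a lower number a less soluble compound), compound 1 holds the lower of the two numbers at 100 nM and compound 2 the higher at 400 nM with the gap beyond the scatter. Compound 3 `COC(=O)c1cccc(NC(=O)Nc2cc(C)nc3ccccc23)c1` has not been measured. It keeps the core of compound 1 and carries methoxy in place of amino on a carbonyl carbon, with the change counted as methoxy in place of amino on a carbonyl carbon here. Among the measured compounds shown here, no pair of measured compounds differs in one place, so the series offers no direct precedent for this change in this assay and the estimate is loose. A small upward step is expected, estimated as a 2.0-fold higher number from compound 1 to compound 3 (0.30 log units; within the scatter) and possibly not beyond the scatter. Compound 3 is expected at 200 nM with an estimated range from 70 nM to 600 nM as its ends.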

Compound 3, solubility: 600 nM
Beside the measured number, compound 3's estimate is 3.0-fold (0.48 log units) below it; the measured number falls inside the stated range.
By their numbers in this assay, from the lowest: compound 1; then compounds 2 and 3 (each within the scatter of the next).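

In this assay, among the compounds shown here, methoxy in place of amino on a carbonyl carbon gives a 6.0-fold higher number from compound 1 to compound 3 (0.78 log units; beyond the scatter) and this is the first one-place step. What sits on this carbonyl carbon, whose other neighbour is an aromatic carbon, therefore moves the number on the core of compound 1 by more than the scatter. Nothing at hand bears on what lies behind the step.

A single step leaves open how other groups on the same carbonyl carbon would read, such as the hydroxyl of a carboxylic acid, a methylamino group or a longer chain like ethoxy in place of methoxy. Also open, from the compounds shown here alone, is whether carbamoyl to methoxycarbonyl would give a step of similar size on any other core.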